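A few compounds are considered here, and "the series" means these few. Any claim that something is new, unique, unknown or untested is made for them only; others in the source may bear on it.

Compound 2, with the structure `CC(Oc1ccccc1S(C)(=O)=O)C1=NCCN1`, gives 316 nM in a functional assay on CHO cells for agonist activity at Alpha-2C adrenergic receptor (Homo sapiens); on this read-out lower numbers stand for an effect already at smaller amounts and higher numbers for an effect only at larger amounts of compound. For the measured compounds named here, it holds the lower of the two numbers measured so far, yet its neighbour compound 1, with the structure `C=COc1ccccc1OC(C)C1=NCCN1`, gives 631 nM in this assay, and the single measured step, a 2.0-fold lower number from compound 1 to compound 2 (0.30 log units; within the scatter), keeps the two within the usual scatter, so no order between them is claimed. The next compound, compound 3, has the structure `CC(=O)c1ccccc1OC(C)C1=NCCN1` and has not yet been measured in this assay. Its change from compound 2 is acetyl in place of methylsulfonyl on an aromatic carbon. Going by the values given here, the only step that bears on this change is the one from compound 1 to compound 2, which alters the same aromatic carbon and leaves the rest of the shared core untouched; that step was within the scatter. On that evidence alone, no step beyond the scatter is expected in this assay for compound 3, in either direction. Compound 3 is therefore estimated at 400 nM, with a range from 130 nM to 1300 nM, which corresponds to an expected step of a 1.3-fold higher number from compound 2 to compound 3 (0.10 log units; within the scatter).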

Compound 3, half-maximal effective concentration: 200 nM
Compound 3: middle estimate off by 2.0-fold (0.30 log units), on the high side, and the stated range covers the measured number.
By their numbers in this assay, from the lowest: compounds 3, 2 and 1 (each within the scatter of the next, the first and the last beyond it).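

In this assay, replacing methylsulfonyl, with its 4 heavy atoms and 2 hydrogen-bond acceptors, by acetyl, with 3 heavy atoms and 1 hydrogen-bond acceptor, gives a 1.6-fold lower number from compound 2 to compound 3 (0.20 log units; within the scatter), so these two groups cannot be told apart on this aromatic carbon. The same carbon nevertheless yields its first step beyond the scatter, a 3.2-fold lower number from compound 1 to compound 3 (0.50 log units; beyond the scatter), a modest step for acetyl in place of vinyloxy that shows the read-out can respond to the group placed there, which the earlier pair of compounds did not show. Nothing available explains this difference between acetyl and vinyloxy.

The compounds shown leave open how an amine or a carboxylic acid on this aromatic carbon would read in this assay, and whether a longer chain on the carbonyl in place of the methyl of acetyl would remain within the scatter of compound 3. They also leave open whether acetyl in place of vinyloxy would give a similar step on any other aromatic carbon of the shared core.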